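The source may report more compounds than this note shows. Statements on the series, on what has been measured and on what is new or still open speak of the compounds shown alone.

Measured compounds in this study:

Compound 1, `Nc1scc(CN2CCN(c3ccc(C(F)(F)F)cc3)CC2)c1C(=O)c1cccc(C(F)(F)F)c1`, read as -12% in a functional assay on CHO cells with adenosine receptor A1 (Homo sapiens) as the target, read by cAMP accumulation and immunoassay, with a stated time of 6 min, tested at 0.01 uM; on this read-out lower numbers stand for a stronger effect and higher numbers for a weaker effect at the one concentration tested.
Compound 2, `Nc1scc(CN2CCN(c3cccc4ccccc34)CC2)c1C(=O)c1ccc(Cl)cc1`, read as 8.7% in this assay.

Of these two numbers, compound 2 stands highest. Among the compounds with values here, its only neighbour, compound 1, lies lower by a gap that is beyond the usual scatter of repeated measurements; both numbers sit close to the zero line of this assay, so neither shows a large effect at the single concentration tested.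

The account now follows the step from compound 2 to compound 3, `Nc1scc(CN2CCN(c3ccc(Cl)c(Cl)c3)CC2)c1C(=O)c1ccc(Cl)cc1`, which has not yet been measured in this assay. Compared with compound 2, the change is 3,4-dichlorophenyl in place of naphthalen-1-yl on an amine nitrogen in a ring. Within the data shown here, no pair of measured compounds differs by this change alone, so no measured step shows what it does on its own; the two values known only show that changing the group on the ring amine nitrogen together with the other ring leaves both compounds near zero.

The step expected from this change, a number 6.7 percentage points lower from compound 2 to compound 3 (within the scatter), is estimated to be small and in no direction beyond the scatter. Compound 3 is therefore expected to read about 2% in this assay, within a range of -15% to 20%.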

Compound 3, a percentage reported as activity, at one concentration (the size of the read-out at that concentration, not a potency): -1.2%
The estimate for compound 3 lay 3.2 percentage points above the measured number, and the stated range covers the measured number.
By their numbers in this assay, from the lowest: compound 1; then compounds 3 and 2 (each within the scatter of the next).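

In this assay, within the data shown here, replacing naphthalen-1-yl with 3,4-dichlorophenyl on the amine nitrogen in the ring gives a number 9.9 percentage points lower from compound 2 to compound 3 (within the scatter), and this is the first view of a change at this position with the rest of the molecule held constant; compounds 1 and 2 differ in more than one place, so their gap could not be assigned to any single part. The fused pair of aromatic rings can thus give way to one chlorine-bearing aromatic ring, with 10 heavy atoms leaving and 8 entering, without a separable change in the read-out at the one concentration tested. No independent evidence accounts for this result or explains why the two groups read alike.

Going by these compounds, whether a plain phenyl, a pyridin-2-yl or a benzyl group on the same nitrogen would also stay within the scatter of compound 2 remains open. Also open, on these data alone, is whether compound 2 and compound 3 would remain indistinguishable at other concentrations, since a single-concentration read-out gives no potency.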